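A few compounds are considered here, and "the series" means these few. Any claim that something is new, unique, unknown or untested is made for them only; others in the source may bear on it.

Measured so far:

compound 1, `C=C1[C@H](OCC(C)C)C[C@@H](OC(=O)c2cccnc2)C(C)(C)/C=C/[C@@H](C)C(=O)[C@@]2(OC(C)=O)C[C@H](C)[C@H](OC(C)=O)[C@@H]2[C@H]1OC(C)=O`, 16.4%
compound 2, `C=C1[C@H](OC(C)=O)C[C@@H](OC(C)=O)C(C)(C)/C=C/[C@@H](C)C(=O)[C@@]2(OC(C)=O)C[C@@](C)(OC(C)=O)[C@H](OC(C)=O)[C@@H]2[C@H]1OC(C)=O`, 29.9%
compound 3, `C=C1[C@H](OCC(C)C)[C@@H](OC(C)=O)[C@@H](OC(C)=O)C(C)(C)[C@@H]2O[C@](O)([C@H](C)[C@@H]2OC(C)=O)[C@@]2(OC(C)=O)C[C@@](C)(OC(C)=O)[C@H](OC(C)=O)[C@@H]2[C@H]1OC(C)=O`, 17.7%

In a functional assay on Ishikawa cells (Homo sapiens) for inhibition, read by MTT assay, with a stated time of 72 h, tested at 30 ug/mL (a higher number here means more inhibition of growth at the concentration tested, a lower number less inhibition of growth), compound 2 gives 29.9% and stands highest of the three numbers. Its nearest neighbour on the numbers is compound 3, which in this assay gives 17.7%, a gap beyond the scatter. Furthest is compound 1, which in this assay gives 16.4%, also beyond the scatter. For the measured compounds named here, compound 1 and compound 3 differ from compound 2 in more than one place, so their numbers are taken only as what they are; no single-change step among the measured compounds is available.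

Compound 4, `C=C1[C@H](OC(C)=O)C[C@@H](OC(=O)c2cccnc2)C(C)(C)/C=C/[C@@H](C)C(=O)[C@@]2(OC(C)=O)C[C@@](C)(OC(C)=O)[C@H](OC(C)=O)[C@@H]2[C@H]1OC(C)=O`, has not yet been measured. It differs from compound 2 in one place: pyridin-3-yl in place of methyl on a carbonyl carbon. Compound 1 also carries a (pyridin-3-yl)carbonyl at an acetoxy position of the shared core and sits lowest of the three, but it differs from compound 2 elsewhere as well, so that comparison carries little weight. Going by the values given here, with no single-change step to rest on, the expectation for the step from compound 2 to compound 4 in this assay is a modest lowering, a number 5.9 percentage points lower from compound 2 to compound 4 (within the scatter), of a size that may not reach beyond the scatter. Compound 4 is accordingly expected to give about 24% in this assay, within a range from 12% to 36%.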

Compound 4, percent growth inhibition at one concentration: 13.9%
Estimate against measurement, compound 4: 10.1 percentage points above; the measured number falls inside the stated range.
By their numbers in this assay, from the lowest: compounds 4, 1 and 3 (each within the scatter of the next); then compound 2.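

For the compounds shown here, the first single-change step reads, in this assay, a number 16 percentage points lower from compound 2 to compound 4 (beyond the scatter), with pyridin-3-yl in place of methyl on a carbonyl carbon. This shows that the change from acetoxy to ((pyridin-3-yl)carbonyl)oxy at this position of the shared core is enough on its own to lower growth inhibition, something compounds 1 and 3 could not show, as each differs from compound 2 in more than one place. No measurement among those shown accounts for the lowering, so it stands as an observation without an established cause.

As far as these compounds go, whether the lowering depends on the ring nitrogen of the pyridin-3-yl group, on the aromatic ring, or simply on replacing acetyl with a larger acyl group stays open; a benzoyl group or a butanoyl chain at the same position would begin to separate these readings. Also open, from the compounds shown here alone, is whether the same step appears when the (pyridin-3-yl)carbonyl group stands at another acetoxy position, and whether it holds over a full concentration series rather than at a single test concentration.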